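A Piperazine in Place of the Hydroxyethylamine

The source may hold more compounds than are shown below. What is called first, only, known or untested is meant among the compounds shown, and "the series" means these compounds.

Compound 3 `Cc1cc(NCCO)nc(SCc2nc3ccccc3[nH]2)n1` stands at the top end of the numbers seen: in a functional assay on MGC-803 cells (Homo sapiens) for cytotoxicity, read by MTT assay, with a stated time of 72 h (on this read-out lower numbers stand for stronger inhibition and higher numbers for weaker inhibition), compound 3 gives > 100000 nM, which is a limit of the assay rather than a number (the limit of > 100000 nM in this assay, at which 2 of the 3 values shown sit). Compound 1 `Cc1cc(NC(C)C)nc(SCc2nc3ccccc3[nH]2)n1` likewise gives > 100000 nM, again a limit. Compound 2 `Cc1cc(Nc2ccc(Cl)cc2)nc(SCc2nc3ccccc3[nH]2)n1` gives 28200 nM in this assay. Compound 4 `Cc1cc(N2CCNCC2)nc(SCc2nc3ccccc3[nH]2)n1` differs from compound 3 by piperazin-1-yl in place of (2-hydroxyethyl)amino on an aromatic carbon. Within the data shown here, two measured steps bear on it: an at least 3.5-fold higher number from compound 2 to compound 3 (0.54 log units; beyond the scatter) and an at least 3.5-fold lower number from compound 1 to compound 2 (0.54 log units; beyond the scatter), while a step that the two limits leave unreadable from compound 1 to compound 3 cannot be sized. Both compounds carrying a small amine on that carbon sit at the limit, and the piperazin-1-yl of compound 4 is another small amine. Compound 4 is therefore expected to show a number no higher from compound 3 to compound 4 (the limit leaves the size open), an estimated value of 100000 nM with a range from 30000 nM to 300000 nM.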

Compound 4, half-maximal inhibitory concentration: > 100000 nM
Compound 4 gave a limit, no number; the forecaster's own chance of this, stated with the estimate: 60%; the middle value lies on the limit itself.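

Compound 4 gives > 100000 nM in this assay, which is a limit and not a number, so an amine held in a ring now joins the two open-chain amines there: the limit of > 100000 nM in this assay, at which 3 of the 4 values shown sit. Putting piperazin-1-yl in place of (4-chlorophenyl)amino gives an at least 3.5-fold higher number from compound 2 to compound 4 (0.54 log units; beyond the scatter), and of the four groups shown on this carbon, only (4-chlorophenyl)amino gives a readable number. The steps linking compound 1, compound 3 and compound 4 cannot be read. From the compounds shown here alone, whether a phenylamino group without the chlorine, or a benzylamino group, would also give a readable number stays open.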